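A few compounds are considered here, and "the series" means these few. Any claim that something is new, unique, unknown or untested is made for them only; others in the source may bear on it.

Among the measured compounds shown here, in a functional assay on KB cells (Homo sapiens) for inhibition, read by MTT assay, with a stated time of 24 h, tested at 10 ug/mL (on this read-out lower numbers stand for less inhibition of growth and higher numbers for more inhibition of growth at the one concentration tested), compound 1 `CC(=O)SCCC(CCCCC(=O)O)SC(C)=O` gives 8.88%, the only actual number in this small set, and a low one on that scale. Compound 2 `O=C(CCCCC1CCSS1)Nc1ccc([N+](=O)[O-])c(C(F)(F)F)c1` is recorded as "not active" (no number reported), and compound 3 `O=C(CCCCC1CCSS1)Nc1cccc2ccccc12` is recorded as "not active" (no number reported), so neither offers a figure for comparison.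

Compound 4 `CC(=O)SCCC(CCCCC(=O)Nc1ccccc1Cl)SC(C)=O` keeps the core of compound 1 and changes one end of the molecule: (2-chlorophenyl)amino in place of hydroxy on a carbonyl carbon. Put simply, (2-chlorophenyl)amino stands in place of hydroxy on a carbonyl carbon. For the measured compounds named here, no measured pair shows what this kind of change does here. Compounds 2 and 3 are also amides, but they differ from compound 4 elsewhere in the structure, so they are only a loose guide. Even so, compound 2 at "not active" (no number reported) and compound 3 at "not active" (no number reported) give no reason to expect a large gain in this assay. The expected a number 5.1 percentage points higher from compound 1 to compound 4 (within the scatter) is a small rise, not clearly beyond the usual scatter. For compound 4 the estimated value is 14%, within an expected range of 0% to 40%.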

Compound 4, percent growth inhibition at one concentration: 6.55%
Beside the measured number, compound 4's estimate is 7.5 percentage points above it; measured number inside the range.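

Among the compounds shown here, replacing hydroxy with (2-chlorophenyl)amino on a carbonyl carbon gives the first measured pair in this set, and in this assay it amounts to a number 2.3 percentage points lower from compound 1 to compound 4 (within the scatter). At this one position, then, a group with an aromatic ring in place of hydroxy leaves compound 4 indistinguishable from compound 1, and the amide does not bring the clear gain in growth inhibition that a larger group might have been hoped to give. No measurement available here bears on why the two compounds read alike.

As far as these compounds go, it remains open whether a different group on the same carbonyl carbon, such as benzylamino, morpholine or a methyl ester, would separate from compound 1. A single pair also cannot show whether a phenylamino group without the chlorine would read the same.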